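A few compounds are considered here, and "the series" means these few. Any claim that something is new, unique, unknown or untested is made for them only; others in the source may bear on it.

Measured so far:
- compound 1, `CCOC(=O)c1cnc(NC2CC2)n2nc(-c3ccco3)nc12`: 60.7 nM
- compound 2, `CCNc1ncc(C(=O)O)c2nc(-c3ccco3)nn12`: 11900 nM

In an assay on CHO cells for displacement of a labelled ligand from adenosine receptor A1 (Homo sapiens) (on this read-out lower numbers stand for stronger inhibition and higher numbers for weaker inhibition), compound 1 gives 60.7 nM. In this assay compound 2 gives 11900 nM, the highest of the two numbers seen; its nearest neighbour is compound 1, whose number is lower by a margin well beyond the scatter. Going by the values given here, the two compounds differ in more than one place, so no single step between them is defined; the pair only shows how far apart the two ends of the series lie.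

Compound 3, `O=C(O)c1cnc(NCc2ccc(F)cc2)n2nc(-c3ccco3)nc12`, is not yet measured. It is derived from compound 2 by the change (4-fluorophenyl in place of methyl on a saturated chain carbon bound to a nitrogen on an aromatic ring), the acid and the shared core being kept. Among the compounds with values here, no measured pair carries this change, so the direction of the step rests on nothing tested here. The working expectation is a moderate move to a lower number in this assay, estimated as a 4.0-fold lower number from compound 2 to compound 3 (0.60 log units; beyond the scatter), with wide uncertainty in both directions. For compound 3 the estimated value in this assay is 3000 nM, expected to fall between 600 nM and 15000 nM.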

Compound 3, inhibition constant: > 100000 nM
Compound 3: a limit, no number (the forecaster's own chance of this, stated with the estimate: 5%); middle value at least 33-fold (1.52 log units) away from the limit.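

With the acid and the shared core kept, 4-fluorophenyl in place of methyl on a saturated chain carbon bound to a nitrogen on an aromatic ring gives, in this assay, an at least 8.4-fold higher number from compound 2 to compound 3 (0.92 log units; beyond the scatter), so this position is not indifferent to the change, and the move runs toward weaker inhibition rather than stronger. Compound 3 sits at > 100000 nM, which is a limit of the assay and not a number. The step therefore fixes only a minimum size for the change from ethyl to 4-fluorobenzyl, and how far compound 3 actually lies from compound 2 remains unknown: the limit of > 100000 nM in this assay, at which 1 of the 3 values shown sits.

Going by these compounds alone, with only this one change, the result does not separate the contribution of the phenyl ring from that of the fluorine, and a plain benzyl or a propyl chain on the same nitrogen would be needed to tell them apart. As far as these compounds go, whether the change from ethyl to 4-fluorobenzyl runs the same way with an ethyl ester or a primary amide in place of the carboxylic acid also stays open, since compound 1 differs from both acids in more than one place.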